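The compounds below may be only part of what the source reports. "The series", "measured", "known", "first", "only" and "open" are said of these compounds alone.

Going by the values given here, in a functional assay on QGY-7703 cells (Homo sapiens) for cytotoxicity, read by MTT assay, with a stated time of 24 h (on this read-out lower numbers stand for stronger inhibition and higher numbers for weaker inhibition), two compounds that share one core have numbers so far. Compound 1 `O=C1/C(=C/c2cccnc2)CN(S(=O)(=O)c2ccccc2)C/C1=C\c1ccccc1C(F)(F)F` gives 6240 nM, and compound 2 `O=C1/C(=C/c2cccnc2)CN(S(=O)(=O)c2ccc(C(F)(F)F)cc2)C/C1=C\c1ccccc1C(F)(F)F` gives 1500 nM, so compound 2 holds the lower of the two numbers. Among the compounds with values here, the only measured step is a 4.2-fold lower number from compound 1 to compound 2 (0.62 log units; beyond the scatter). It is modest but beyond the scatter, and it comes from trifluoromethyl in place of hydrogen on an aromatic carbon.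

Compound 3 `O=C1/C(=C/c2cccnc2)CN(S(=O)(=O)c2ccc(F)cc2)C/C1=C\c1ccccc1C(F)(F)F` keeps the core of compound 2 and alters that same carbon: fluoro in place of trifluoromethyl on an aromatic carbon. This is fluoro in place of trifluoromethyl on an aromatic carbon, para to a large group. Within the data shown here, no compound with fluoro at this place has been measured, so the evidence is indirect. Among the measured compounds shown here, the step to compound 2, a 4.2-fold lower number from compound 1 to compound 2 (0.62 log units; beyond the scatter), is the only guide to what leaving trifluoromethyl might cost, and it suggests that part of that gain could be lost. The expected change is therefore upward and smaller than that step, namely a 2.0-fold higher number from compound 2 to compound 3 (0.30 log units; within the scatter), and it may prove hard to separate from the scatter. Compound 3 is expected at about 3000 nM, with an estimated range from 1200 nM to 6500 nM.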

Compound 3, half-maximal inhibitory concentration: 6030 nM
For compound 3 the middle estimate is 2.0-fold (0.30 log units) below the measured one, within the range that was stated.
By their numbers in this assay, from the lowest: compound 2; then compounds 3 and 1 (each within the scatter of the next).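

In this assay, the lower number of compound 2 proves specific to trifluoromethyl rather than a general result of replacing hydrogen at this carbon, para to a large group: fluoro in place of trifluoromethyl gives a 4.0-fold higher number from compound 2 to compound 3 (0.60 log units; beyond the scatter). Fluoro in place of hydrogen on the same carbon gives a 1.0-fold lower number from compound 1 to compound 3 (0.01 log units; within the scatter), so fluoro and hydrogen cannot be told apart here, and of the three groups compared only trifluoromethyl separates from the others beyond the scatter. Nothing available explains why these two fluorine-bearing groups differ at this position.

The compounds shown cover only hydrogen, fluoro and trifluoromethyl at this carbon, so it remains open whether a methoxy group, an amine, a carboxylic acid or a longer chain here would match the number of compound 2, improve on it, or fall back to the level shared by compound 1 and compound 3. As far as these compounds go, it also remains open whether the advantage of the 4-(trifluoromethyl)phenyl group would persist if the other parts of the shared core were changed.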